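Bromine placement on the sulfur-bound phenyl group

The source may hold more compounds than are shown below. What is called first, only, known or untested is meant among the compounds shown, and "the series" means these compounds.

In a functional assay on DU-145 cells (Homo sapiens) for inhibition, read by trypan blue exclusion, with a stated time of 96 h (a higher number here means a weaker inhibitor of growth, a lower number a stronger inhibitor of growth), compound 1 `Cc1ccc(CS/C(=C/c2c(O)cc(O)cc2O)C(=O)c2ccc(Cl)cc2)cc1` gives 50000 nM. Compound 2 `O=C(/C(=C\c1c(O)cc(O)cc1O)SCc1ccc(Cl)cc1)c1ccc(Cl)cc1` is reported only as a limit, > 100000 nM. Compound 3 `O=C(/C(=C\c1c(O)cc(O)cc1O)Sc1ccc(Br)cc1)c1ccc(Cl)cc1` gives 50000 nM, which places it level with compound 1 at the digits shown.

Compound 4 `O=C(/C(=C\c1c(O)cc(O)cc1O)Sc1ccccc1Br)c1ccc(Cl)cc1` carries 2-bromophenyl in place of 4-bromophenyl on a sulfur. The two compounds have the same atoms, joined differently. Among the measured compounds shown here, no measured pair isolates this kind of change, so the evidence is indirect. The two measured changes on the sulfur are no change at the digits printed from compound 1 to compound 3 (within the scatter) and an at least 2.0-fold lower number from compound 2 to compound 3 (0.30 log units; that floor lies within the scatter). The remaining measured change, on an aromatic carbon, is an at least 2.0-fold higher number from compound 1 to compound 2 (0.30 log units; that floor lies within the scatter). None of these three steps is shown to exceed the scatter, although the two involving the limit are only bounds. On this evidence, no step beyond the scatter is expected in this assay, and no direction can be favoured. The expected step is no change at the digits printed from compound 3 to compound 4 (within the scatter). Because compound 2 stands at > 100000 nM, a result reported only as a limit remains a real possibility. The estimated value for compound 4 is 50000 nM, with an expected range from 20000 nM to 100000 nM.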

Compound 4, concentration for 50% growth inhibition: > 100000 nM
Compound 4 gave a limit, no number; the forecaster's own chance of this, stated with the estimate: 25%; middle value at least 2.0-fold (0.30 log units) away from the limit.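

Compound 4 is a limit of the assay, not a number, in this assay: > 100000 nM. This is the only pair shown that changes bromine placement alone on the sulfur-bound phenyl group, and it gives an at least 2.0-fold higher number from compound 3 to compound 4 (0.30 log units; that floor lies within the scatter), while the change from the 4-methylbenzyl group gives an at least 2.0-fold higher number from compound 1 to compound 4 (0.30 log units; that floor lies within the scatter); neither step points to a gain from 2-bromophenyl, although neither is shown to exceed the scatter. The step between compound 2 and compound 4 cannot be read, and the series now shares one ceiling: the limit of > 100000 nM in this assay, at which 2 of the 4 values shown sit.

As far as these compounds go, how far compound 4 actually lies from compound 3 remains open, so the effect of bromine placement has a direction only as a bound and no size. From the compounds shown here alone, it is also open whether replacing the bromine with an amine or a carboxylic acid, or placing a longer chain on the sulfur, would give a readable value beneath that ceiling.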